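The source may report more compounds than this note shows. Statements on the series, on what has been measured and on what is new or still open speak of the compounds shown alone.

Measured compounds:
compound 1, `CCn1ccc2cc(-c3ccc4oc(NC5CCCCC5)nc4c3)ccc21`, giving 207 nM
compound 2, `c1cc2c(ccn2C2COC2)cc1-c1ccc2oc(NC3CCCCC3)nc2c1`, giving 579 nM

Among the compounds with values here, in an assay on HEK293 cells for inhibition of Fatty-acid amide hydrolase 1 (Homo sapiens), read by fluorescence (on this read-out higher numbers stand for weaker inhibition and lower numbers for stronger inhibition), compound 2 stands highest of the two numbers, with compound 1 as its only neighbour: a 2.8-fold higher number from compound 1 to compound 2 (0.45 log units; beyond the scatter). Compound 3, `NC(=O)Cn1ccc2cc(-c3ccc4oc(NC5CCCCC5)nc4c3)ccc21`, differs from compound 2 in one place: carbamoylmethyl in place of oxetan-3-yl on an aromatic nitrogen. Within the data shown here, that earlier step sits on the same aromatic nitrogen and shows that swapping the group there can move the number beyond the scatter, but no measured step involves carbamoylmethyl, so its direction is unknown. The expected step is therefore small, a 1.2-fold lower number from compound 2 to compound 3 (0.06 log units; within the scatter), with a wide range. The estimate for compound 3 is 500 nM, between 150 nM and 1800 nM.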

Compound 3, half-maximal inhibitory concentration: 214 nM
Beside the measured number, compound 3's estimate is 2.3-fold (0.37 log units) above it; low and high end bracket the measured number.
By their numbers in this assay, from the lowest: compounds 1 and 3 (each within the scatter of the next); then compound 2.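

Replacing the ring of oxetan-3-yl with the open carbamoylmethyl chain on this aromatic nitrogen gives a 2.7-fold lower number from compound 2 to compound 3 (0.43 log units; beyond the scatter) and so recovers the ground lost with oxetan-3-yl. Against the ethyl compound, carbamoyl in place of methyl gives a 1.0-fold higher number from compound 1 to compound 3 (0.01 log units; within the scatter) and no change that can be told from scatter, so this nitrogen tolerates both chains alike. Nothing available explains why oxetan-3-yl stands apart from these two groups.

Still open, on these data alone, is how a carboxylic acid, an amine or a longer chain on this nitrogen would compare with ethyl and carbamoylmethyl.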